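A few compounds are considered here, and "the series" means these few. Any claim that something is new, unique, unknown or untested is made for them only; others in the source may bear on it.

Of the compounds shown here, three that share one core have so far been tested in a functional assay on the whole organism for inhibition, with Rattus norvegicus as the target, at a dose of 25 mg/kg by the intraperitoneal route; on this read-out lower numbers stand for less inhibition and higher numbers for more inhibition at the one dose given (going by the name of the read-out). Compound 1 `Cc1ccc(Cn2cnc3c(N(C)C)ncnc32)cc1` gives 0% in this assay. Compound 2 `CN(C)c1ncnc2c1ncn2Cc1ccc(C#N)cc1` carries a cyano in place of methyl on an aromatic carbon, and in this assay compound 2 gives 0%; that change amounts to no change at the digits printed from compound 1 to compound 2 (within the scatter). Compound 3 `CN(C)c1ncnc2c1ncn2CC1CCCCC1` gives 0% in this assay. Compound 3 thus stands level with compounds 1 and 2 at the digits shown, and none of the three is separated from another by more than the usual scatter.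

The step of interest leads from compound 3 to compound 4 `CN(C)c1ncnc2c1ncn2C`. The change is hydrogen in place of cyclohexyl on a saturated chain carbon bound to an aromatic nitrogen, so the group on the saturated chain carbon bound to the aromatic nitrogen is taken away. Within the data shown here, the only measured step, no change at the digits printed from compound 1 to compound 2 (within the scatter), concerns an aromatic carbon elsewhere in the molecule and showed no movement. Among the measured compounds shown here, no measured step varies the saturated chain carbon itself, and the three measured compounds give no sign that a group at this place shifts the read-out. The expected step is therefore no change at the digits printed from compound 3 to compound 4 (within the scatter), with no movement beyond the scatter. Compound 4 is expected to give 0%, with a range from -5% to 10%.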

Compound 4, a percentage reported as inhibition, in the whole organism at one dose (the size of the read-out at that dose, not a potency): 30%
For compound 4 the middle estimate is 30 percentage points below the measured one; measured number above the stated range.
By their numbers in this assay, from the lowest: compounds 1, 2 and 3 (each within the scatter of the next); then compound 4.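

Going from cyclohexyl to hydrogen on the saturated chain carbon bound to the aromatic nitrogen gives, in this assay, a number 30 percentage points higher from compound 3 to compound 4 (beyond the scatter), the only step shown that lies beyond the scatter. The earlier step, a cyano in place of methyl on an aromatic carbon, gave no change at the digits printed from compound 1 to compound 2 (within the scatter), so it said nothing about this other place; the new step shows that what is attached to this saturated chain carbon can shift the read-out, and that the shift can come from taking a group away rather than adding one. No measurement here accounts for the rise, so the reason for it remains unknown.

Hydrogen and cyclohexyl are very different in size, and the compounds shown do not reveal what happens at this place with something in between, such as a methyl group, an ethyl chain or a smaller ring like cyclopropyl, or with an amine or a carboxylic acid on a short chain. As this assay reports a single dose, they also leave open how the inhibition of compound 4 would change at other doses.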